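Arylpiperazine series: second methyl on the 3-methylphenyl of compound 2

The source may hold more compounds than are shown below. What is called first, only, known or untested is meant among the compounds shown, and "the series" means these compounds.

Of the compounds shown here, two have been measured in an assay on HEK293 cells for inhibition of Voltage-dependent T-type calcium channel subunit alpha-1G (Homo sapiens), read by patch clamp; on this read-out lower numbers stand for stronger inhibition and higher numbers for weaker inhibition. Compound 1 `CCCc1nc(-c2ccccc2)c(CNCCCN2CCN(c3ccccc3Cl)CC2)o1` gives 2800 nM, and compound 2 `CCCc1nc(-c2ccccc2)c(CNCCCN2CCN(c3cccc(C)c3)CC2)o1` gives 1190 nM. Within the data shown here, the single measured step, a 2.4-fold lower number from compound 1 to compound 2 (0.37 log units; beyond the scatter), leaves compound 2 with the lowest of the two numbers so far. Compound 3 `CCCc1nc(-c2ccccc2)c(CNCCCN2CCN(c3ccc(C)c(C)c3)CC2)o1` is not yet measured; it differs from compound 2 by methyl in place of hydrogen on an aromatic carbon. Among the measured compounds shown here, no measured step covers this change directly: a 2.4-fold lower number from compound 1 to compound 2 (0.37 log units; beyond the scatter) exchanges the whole aryl group on the amine nitrogen in a ring, so it only shows that changes at this part of the molecule can move the number beyond the scatter. The added methyl is a small change, and a step of a 1.2-fold lower number from compound 2 to compound 3 (0.08 log units; within the scatter) is expected, which is within the scatter. The estimate for compound 3 in this assay is 1000 nM, with a range from 400 nM to 2500 nM.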

Compound 3, half-maximal inhibitory concentration: 3020 nM
The estimate for compound 3 lay 3.0-fold (0.48 log units) below the measured number; the measured number lies above the stated range.
By their numbers in this assay, from the lowest: compound 2; then compounds 1 and 3 (each within the scatter of the next).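

In this assay, one added methyl on the aromatic carbon ortho to a methyl group and para to a large group gives a 2.5-fold higher number from compound 2 to compound 3 (0.40 log units; beyond the scatter) and lies beyond the scatter, so adding a single heavy atom at this position of the 3-methylphenyl group can change the number measurably. The step of a 1.1-fold higher number from compound 1 to compound 3 (0.03 log units; within the scatter) lies within the scatter, so the lower number seen with 3-methylphenyl does not carry over to 3,4-dimethylphenyl, which cannot be told apart from 2-chlorophenyl here. No evidence is available on what lies behind the step at this position.

Going by these compounds, whether methoxy, fluorine or hydroxyl at the same place would move the number as methyl does remains open. Also open, on these data alone, is whether the added methyl would have a similar effect on the 2-chlorophenyl group of compound 1.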